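The compounds below may be only part of what the source reports. "The series", "measured", "known", "first", "only" and "open" are said of these compounds alone.

Measured compounds:
compound 1 `CNC(=O)c1cc(Oc2ccc3nc(NC(=O)c4ccc(Cl)cc4)sc3c2)ccn1` with 18.9%
compound 2 `CNC(=O)c1cc(Oc2ccc3nc(NC(=O)Nc4ccc(C5CCN(C(C)C)CC5)cc4)sc3c2)ccn1` with 45%

For the measured compounds named here, in a functional assay on SK-BR-3 cells (Homo sapiens) for inhibition, read by MTT assay, with a stated time of 2 days, tested at 10 uM (on this read-out higher numbers stand for more inhibition of growth at the one concentration tested and lower numbers for less inhibition of growth), compound 2 stands highest of the two numbers known so far; compound 1 is the nearest and lies a stretch below it that goes beyond the usual scatter. The two differ in more than one place, so the part of that gap that belongs to any single change cannot be separated out from what is known.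

Compound 3 `CNC(=O)c1cc(Oc2ccc3nc(NC(=O)Nc4ccc(Br)cc4)sc3c2)ccn1` has not yet been measured in this assay. It is reached from compound 2 by a single change: bromo in place of 1-isopropylpiperidin-4-yl on an aromatic carbon. Going by the values given here, no step between measured compounds isolates this change, so its effect cannot be read off directly; the only other halogen-bearing compound, compound 1, carries a different linker as well and gives the lower of the two values.

On that basis compound 3 is expected to fall back from compound 2 by a step of a number 15 percentage points lower from compound 2 to compound 3 (beyond the scatter), sitting between the two measured numbers. The estimate for compound 3 is 30%, with a range from 10% to 50%.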

Compound 3, percent growth inhibition at one concentration: 26.7%
For compound 3 the middle estimate is 3.3 percentage points above the measured one, within the range that was stated.
By their numbers in this assay, from the lowest: compounds 1 and 3 (each within the scatter of the next); then compound 2.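

In this assay, for the compounds shown here, putting bromo in place of 1-isopropylpiperidin-4-yl on the aromatic carbon gives a number 18.3 percentage points lower from compound 2 to compound 3 (beyond the scatter), which for the first time ties a single change at this place to a step beyond the scatter, with the 1-isopropylpiperidin-4-yl compound holding the higher number. The other step, a number 7.8 percentage points higher from compound 1 to compound 3 (within the scatter), puts (4-bromophenyl)amino in place of 4-chlorophenyl on the carbonyl carbon and lies within the scatter, so the two halogen-bearing compounds cannot be told apart on this read-out. Nothing among the data on hand accounts for the step at this position.

The compounds shown leave open whether the higher number follows the isopropyl group on the ring nitrogen, the piperidine ring itself or simply a larger group at this place, a question that piperidin-4-yl without the isopropyl, morpholin-4-yl or a dimethylamino group would address. They also leave open whether chloro, methoxy or a plain hydrogen at this place would read like bromo, and how any of these compounds would behave away from the one concentration tested.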